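Toward a hydroxyphenyl ketone on the boron-bearing core

The source may report more compounds than this note shows. Statements on the series, on what has been measured and on what is new or still open speak of the compounds shown alone.

Three enone ketones on a shared core have been tested in a functional assay on SK-OV-3 cells (Homo sapiens) for cytotoxicity, read by MTT assay, with a stated time of 48 h; a higher number here means a weaker inhibitor, a lower number a stronger inhibitor. Compound 1 `O=C(/C=C/c1ccc2c(c1)B(O)OC2)c1cccnc1` gives 18500 nM, the highest of the three numbers. Compound 2 `O=C(/C=C/c1ccc2c(c1)B(O)OC2)c1ccc(I)cc1` gives 4200 nM, and compound 3 `O=C(/C=C/c1ccc2c(c1)B(O)OC2)c1ccc([N+](=O)[O-])cc1` gives 7900 nM. Compound 1 and compound 3 are not linked by a single-point step; their two values simply show compound 3 with the lower number, a gap beyond the scatter.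

Compound 4 `O=C(/C=C/c1ccc2c(c1)B(O)OC2)c1ccccc1O` has not yet been measured. It differs from compound 1 in one place: 2-hydroxyphenyl in place of pyridin-3-yl on a carbonyl carbon. The step of a 4.4-fold lower number from compound 1 to compound 2 (0.64 log units; beyond the scatter) bears most directly on this change, as it also exchanged pyridin-3-yl for a carbon-only ring on the carbonyl carbon and gave a modest lowering beyond the scatter. The step of a 1.9-fold higher number from compound 2 to compound 3 (0.27 log units; within the scatter) shows that swapping one substituent on that ring for another left the number within the scatter. Among the compounds with values here, no measured compound carries 2-hydroxyphenyl, so the size of the expected step is uncertain. On this basis compound 4 is expected to show a modest lowering, estimated at 8000 nM with a range from 3000 nM to 25000 nM. That expectation corresponds to a 2.3-fold lower number from compound 1 to compound 4 (0.36 log units; beyond the scatter).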

Compound 4, half-maximal inhibitory concentration: 48800 nM
The estimate for compound 4 lay 6.1-fold (0.79 log units) below the measured number; the whole stated range lies below it.
By their numbers in this assay, from the lowest: compounds 2 and 3 (each within the scatter of the next); then compound 1; then compound 4.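

In this assay, 2-hydroxyphenyl in place of pyridin-3-yl on the carbonyl carbon raises the number (a 2.6-fold higher number from compound 1 to compound 4 (0.42 log units; beyond the scatter)), whereas 4-iodophenyl in the same place had lowered it (a 4.4-fold lower number from compound 1 to compound 2 (0.64 log units; beyond the scatter)), so replacing pyridin-3-yl with a ring of carbon only does not by itself set the direction of the change. The two carbon-only rings of compound 2 and compound 4 also lie far apart (a 12-fold higher number from compound 2 to compound 4 (1.07 log units; beyond the scatter)), a large step that contrasts with the exchange of iodo for nitro, which stayed within the scatter (a 1.9-fold higher number from compound 2 to compound 3 (0.27 log units; within the scatter)), and this shows that the outcome at this position can depend strongly on which substituted ring is attached. Nothing measured on these compounds accounts for the rise seen with 2-hydroxyphenyl.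

Going by these compounds, whether that rise belongs to the hydroxyl itself remains open, and a phenyl ring carrying a methoxy group or an amine in its place would help to separate the hydroxyl from the ring that bears it. On these data alone, all four compounds also keep the same enone link to the shared core, so it remains open whether these differences would hold with a longer chain between the carbonyl and the core.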